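Sulfonyl aryl substitution in the hydroxy-amide series

The source may hold more compounds than are shown below. What is called first, only, known or untested is meant among the compounds shown, and "the series" means these compounds.

Measured compounds:
compound 1 `CC(O)(C(=O)Nc1ccc(S(=O)(=O)c2ccc(F)cc2)cc1)C(F)(F)F` — 8600 nM
compound 2 `CC(O)(C(=O)Nc1ccc(C#N)c(S(=O)(=O)c2ccccc2)c1)C(F)(F)F` — 2600 nM
compound 3 `CC(O)(C(=O)Nc1ccc(S(=O)(=O)c2ccccc2Cl)cc1)C(F)(F)F` — 2300 nM

In a functional assay (Cavia porcellus) with sulfonylurea receptors; K-ATP channels (Homo sapiens) as the target (a lower number here means a stronger inhibitor, a higher number a weaker inhibitor), compound 1 stands highest of the three numbers, with compound 2 and compound 3 both beyond the scatter below it. Compound 4 `Cc1ccc(S(=O)(=O)c2ccc(NC(=O)C(C)(O)C(F)(F)F)cc2)cc1` is not yet measured. It differs from compound 1 by methyl in place of fluoro on an aromatic carbon. Among the compounds with values here, the only measured step on the sulfonyl aryl, a 3.7-fold lower number from compound 1 to compound 3 (0.57 log units; beyond the scatter), changes both the group and its place at once, so it bears on the new step only loosely; no pair separates the two effects. The step to compound 4 is therefore expected to stay within the scatter, a 1.2-fold lower number from compound 1 to compound 4 (0.09 log units; within the scatter). For compound 4 the estimate in this assay is 7000 nM (range 3000 nM to 17000 nM).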

Compound 4, half-maximal inhibitory concentration: > 30000 nM
Compound 4: only a limit was reported (the forecaster's own chance of this, stated with the estimate: 5%); middle value at least 4.2-fold (0.63 log units) away from the limit.
By their numbers in this assay, from the lowest: compounds 3 and 2 (each within the scatter of the next); then compound 1. At a limit, above all of these: compound 4.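

Methyl in place of fluoro, para to a large group, gives an at least 3.4-fold higher number from compound 1 to compound 4 (0.54 log units; beyond the scatter), so even this exchange of one heavy atom on the sulfonyl aryl is not silent. With 4-methylphenyl in place of 2-chlorophenyl on the sulfonyl sulfur, the series shows an at least 13-fold higher number from compound 3 to compound 4 (1.11 log units; beyond the scatter). Compound 4 is reported only as a limit: the limit of > 30000 nM in this assay, at which 1 of the 4 values shown sits.

As far as these compounds go, whether the same rise follows from a methoxy, an ethyl or an amine in that place remains open. Within the data shown here, no pair carries one group at two places on the sulfonyl aryl, so the effects of group and place remain unseparated.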